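The source may report more compounds than this note shows. Statements on the series, on what has been measured and on what is new or still open speak of the compounds shown alone.

In an assay on CHO cells for displacement of a labelled ligand from Alpha-2B adrenergic receptor (Homo sapiens) (on this read-out lower numbers stand for stronger inhibition and higher numbers for weaker inhibition), compound 2 `CC(Oc1ccccc1-c1ccccc1O)C1=NCCN1` gives 1000 nM. Within the data shown here, only one other compound has been measured alongside it: compound 1 `CC(Oc1ccccc1-c1cccnc1)C1=NCCN1`, which in this assay gives 933 nM. These two numbers lie within the usual scatter of each other, so on the numbers shown compound 2 stands level with compound 1 and nothing separates them.

The step to compound 3 `CC(Oc1ccccc1-c1ccccn1)C1=NCCN1` is pyridin-2-yl in place of 2-hydroxyphenyl on an aromatic carbon. Among the measured compounds shown here, the single measured step that bears on it is a 1.1-fold higher number from compound 1 to compound 2 (0.03 log units; within the scatter), which swapped one aromatic ring for another on the shared core without moving the number beyond the scatter. Compound 3 carries a third such ring on the same core. On that one step, no shift beyond the scatter is expected for compound 3, whose estimate in this assay is 900 nM, with a range from 300 nM to 3000 nM. The expected step is therefore a 1.1-fold lower number from compound 2 to compound 3 (0.05 log units; within the scatter).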

Compound 3, inhibition constant: 3310 nM
Compound 3: middle estimate off by 3.7-fold (0.57 log units), on the low side, and the stated range ends below it.
By their numbers in this assay, from the lowest: compounds 1 and 2 (each within the scatter of the next); then compound 3.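

In this assay, among these compounds, the change to pyridin-2-yl brings the first step beyond the scatter on this aromatic carbon: replacing 2-hydroxyphenyl gives a 3.3-fold higher number from compound 2 to compound 3 (0.52 log units; beyond the scatter) and replacing pyridin-3-yl gives a 3.5-fold higher number from compound 1 to compound 3 (0.55 log units; beyond the scatter) in the same direction. Compound 1 and compound 2 had suggested that one aromatic ring could stand in for another here, but compound 3 shows that this does not hold for every ring. Even two pyridine rings are not interchangeable, so the ring's size and its single hetero atom do not settle the result. The data shown offer no measured explanation for this loss of inhibition.

Still open, as far as these compounds go, is how other aromatic rings, such as pyridin-4-yl or an unsubstituted phenyl, would compare at this position. From the compounds shown here alone, it is also open whether a group that is not a ring, such as an amine or a carboxylic acid, would be tolerated there.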